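The source may report more compounds than this note shows. Statements on the series, on what has been measured and on what is new or still open speak of the compounds shown alone.

In a functional assay on the whole organism (strain Kunming) with Mus musculus as the target, in the formalin test, with a stated time of 0.5 h (on this read-out lower numbers stand for an effect already at smaller amounts and higher numbers for an effect only at larger amounts of compound), compound 1 `COc1ccccc1/C=C/C(=O)OC/C=C/c1cc(OC)c(OC)cc1OC` gives 294 umol/kg and compound 2 `COc1cc(OC)c(OC)cc1/C=C/COC(=O)/C=C/c1ccc(Br)cc1` gives 243 umol/kg, so compound 2 stands within the scatter of compound 1. Compound 3 `COc1cc(OC)c(OC)cc1/C=C/COC(=O)/C=C/c1ccccc1C(F)(F)F` has 2-(trifluoromethyl)phenyl in place of 4-bromophenyl on a double-bonded chain carbon bound to a double-bonded chain carbon. Going by the values given here, one measured step bears on this change, at the same place: a 1.2-fold lower number from compound 1 to compound 2 (0.08 log units; within the scatter). Among the compounds with values here, with only that small step as a guide, no change beyond the scatter is expected in this assay. The expected step is a 1.0-fold higher number from compound 2 to compound 3 (0.01 log units; within the scatter). Compound 3 is estimated at 250 umol/kg, with an expected range of 125 umol/kg to 500 umol/kg.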

Compound 3, dose for half-maximal effect: 291 umol/kg
The estimate for compound 3 lay 1.2-fold (0.07 log units) below the measured number; the measured number falls inside the stated range.
By their numbers in this assay, from the lowest: compounds 2, 3 and 1 (each within the scatter of the next).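

In this assay, 2-(trifluoromethyl)phenyl in place of 4-bromophenyl comes to a 1.2-fold higher number from compound 2 to compound 3 (0.08 log units; within the scatter), so a third substituted phenyl at this position leaves the number within the scatter. Trifluoromethyl in place of methoxy on an aromatic carbon comes to a 1.0-fold lower number from compound 1 to compound 3 (0.00 log units; within the scatter), so this exchange also shows no change beyond the scatter. No measurement is available that bears on these results. Going by these compounds, whether an amine or a carboxylic acid on this phenyl ring would move the number beyond the scatter remains open. So does the effect of a change elsewhere in the shared core.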